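The source may report more compounds than this note shows. Statements on the series, on what has been measured and on what is new or still open speak of the compounds shown alone.

Three measured compounds share an amide that links a piperidine to an aryl group. Compound 3 `O=C1COc2ccc(NC(=O)C3CCN(c4cccc(Br)c4)CC3)cc2N1` gives 330 nM in a functional assay for antagonist activity at transient receptor potential cation channel subfamily V member 1 (Homo sapiens), read by FLIPR and calcium flux (a higher number here means a weaker inhibitor, a lower number a stronger inhibitor), the lowest of the three numbers. Compound 1 `CCOC(=O)C1(C)Oc2ccc(NC(=O)C3CCN(c4cc(F)c(F)c(F)c4)CC3)cc2NC1=O` gives 870 nM in this assay, a gap from compound 3 that lies beyond the usual scatter. Compound 2 `CC(=O)N1CCc2cccc(NC(=O)C3CCN(c4cccc(C(F)(F)F)c4)CC3)c21` gives 5610 nM in this assay, the widest gap from compound 3, also beyond the scatter. Compound 4 `Cc1cccc(N2CCC(C(=O)Nc3ccc4c(c3)NC(=O)CO4)CC2)c1C` is not yet measured; it differs from compound 3 by 2,3-dimethylphenyl in place of 3-bromophenyl on an amine nitrogen in a ring. Among the measured compounds shown here, no measured pair shows the effect of this exchange, so the expected step of a 1.8-fold higher number from compound 3 to compound 4 (0.26 log units; within the scatter) is a mild weakening, not surely beyond the scatter. Compound 4 is therefore estimated at 600 nM, with a range from 200 nM to 2000 nM.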

Compound 4, half-maximal inhibitory concentration: 60 nM
Compound 4: the middle estimate sits 10-fold (1.00 log units) above what was measured; the whole stated range lies above it.
By their numbers in this assay, from the lowest: compound 4; then compound 3; then compound 1; then compound 2.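

In this assay, 2,3-dimethylphenyl in place of 3-bromophenyl on an amine nitrogen in a ring gives a 5.5-fold lower number from compound 3 to compound 4 (0.74 log units; beyond the scatter) and leaves the rest of the structure unchanged, so the aryl group at this position alters the measured number beyond the scatter. Among the compounds shown here, this is the only single-place comparison among the four compounds, and it places compound 4 lowest of them. Nothing measured here explains the step.

Going by these compounds, it remains open whether a single methyl, as in 2-methylphenyl or 3-methylphenyl, would read like the 2,3-dimethylphenyl group. Also open, on these data alone, is whether the same exchange would carry over to the cores of compound 1 and compound 2.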